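The source may report more compounds than this note shows. Statements on the series, on what has been measured and on what is new or still open speak of the compounds shown alone.

Measured in a functional assay on HCT-116 cells (Homo sapiens) for antiproliferative activity, read by sulforhodamine B assay, with a stated time of 4 days; a higher number here means a weaker inhibitor of growth, a lower number a stronger inhibitor of growth:
- compound 1 `COc1cc(Cl)c(-c2nc(SCC(=O)NC3CC3)nc3[nH]cc(C#N)c23)cc1OC`: 60 nM
- compound 2 `COc1cc(Cl)c(-c2nc(SCC(=O)NC3CC3)nc3[nH]cc(C#N)c23)cc1O`: 1160 nM
- compound 3 `CCOc1cc(-c2nc(SCC(=O)NC3CC3)nc3[nH]cc(C#N)c23)c(Cl)cc1OC`: 20 nM

Compound 3 has the lowest number of the three at 20 nM, which makes it the strongest inhibitor of growth in this small set. Compound 4 `CCNC(=O)CSc1nc(-c2cc(OCC)c(OC)cc2Cl)c2c(C#N)c[nH]c2n1` keeps everything in compound 3 except one group, with ethyl in place of cyclopropyl on an amide-type nitrogen.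

Among the compounds with values here, no measured step touches that nitrogen. All three changes lie on the oxygen groups of the aromatic ring. Within the data shown here, two are large, a 19-fold higher number from compound 1 to compound 2 (1.29 log units; beyond the scatter) and a 58-fold lower number from compound 2 to compound 3 (1.76 log units; beyond the scatter), and both involve a bare hydrogen on the oxygen, which has no counterpart here. The closest guide is the modest 3.0-fold lower number from compound 1 to compound 3 (0.48 log units; beyond the scatter), where only a small saturated carbon group changed.

A small move in this assay is therefore expected, perhaps towards a higher number and perhaps no larger than the scatter. The expected step is a 1.5-fold higher number from compound 3 to compound 4 (0.18 log units; within the scatter). For compound 4 the estimate is 30 nM, with an expected range from 10 nM to 90 nM.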

Compound 4, concentration for 50% growth inhibition: 40 nM
The estimate for compound 4 lay 1.3-fold (0.12 log units) below the measured number; the measured number falls inside the stated range.
By their numbers in this assay, from the lowest: compounds 3, 4 and 1 (each within the scatter of the next, the first and the last beyond it); then compound 2.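

This is the first change shown at the amide-type nitrogen, since every earlier step lay on the oxygen groups of the aromatic ring. In this assay, ethyl in place of cyclopropyl gives a 2.0-fold higher number from compound 3 to compound 4 (0.30 log units; within the scatter), so at this position, opening the three-membered ring to a two-carbon chain leaves a step that stays within the scatter. Nothing measured here gives a cause for this result.

The compounds shown carry only cyclopropyl and ethyl on this nitrogen, so it stays open how a longer chain such as butyl, a larger ring such as cyclohexyl, or a chain ending in an amine or a carboxylic acid would behave. On these data alone, whether the same swap would give a similar step on compound 1 also remains open.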